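Ring nitrogen phenylsulfonyl step across two cores

A few compounds are considered here, and "the series" means these few. Any claim that something is new, unique, unknown or untested is made for them only; others in the source may bear on it.

Compound 1 `O=C1/C(=C/c2ccncc2)CNC/C1=C\c1ccccc1F` carries a free amine nitrogen in its six-membered non-aromatic ring. In an ADME assay on L02 cells (Homo sapiens) for cytotoxicity, read by MTT assay, with a stated time of 24 h (on this read-out higher numbers stand for weaker inhibition and lower numbers for stronger inhibition), compound 1 gives 14700 nM. Compound 2 `O=C1/C(=C/c2ccncc2)CN(S(=O)(=O)c2ccccc2)C/C1=C\c1ccccc1F` is its ring-nitrogen phenylsulfonyl analogue, and in this assay compound 2 gives 15900 nM. The change from compound 1 to compound 2 is phenylsulfonyl in place of hydrogen on an amine nitrogen in a ring and it made a 1.1-fold higher number from compound 1 to compound 2 (0.03 log units; within the scatter). Compound 3 `O=C1/C(=C/c2cccnc2)CNC/C1=C\c1ccccc1C(F)(F)F` is built on a different core, and in this assay compound 3 gives 11300 nM. The values of compound 1, compound 2 and compound 3 all lie within the scatter of one another, so no order among the three is drawn. The difference between the core of compound 1 and the core of compound 3 is not broken down here.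

Compound 4 `O=C1/C(=C/c2cccnc2)CN(S(=O)(=O)c2ccccc2)C/C1=C\c1ccccc1C(F)(F)F` has not been measured. Its relation to compound 3 is phenylsulfonyl in place of hydrogen on an amine nitrogen in a ring, the same change as that from compound 1 to compound 2, at the same place in the ring. Among the measured compounds shown here, only one measured instance of this change exists, and that instance stayed within the scatter. On that basis the step from compound 3 to compound 4 is expected to be a 1.1-fold higher number from compound 3 to compound 4 (0.04 log units; within the scatter), set beside the measured 1.1-fold higher number from compound 1 to compound 2 (0.03 log units; within the scatter). Compound 4 is therefore estimated at 12500 nM in this assay, with an expected range from 6000 nM to 26000 nM that reflects the ordinary spread of repeated measurements rather than any anticipated shift.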

Compound 4, half-maximal inhibitory concentration: 12500 nM
For compound 4 middle estimate and measured number coincide at the digits printed; the measured number falls inside the stated range.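

On the core of compound 3, phenylsulfonyl in place of hydrogen on an amine nitrogen in a ring gives a 1.1-fold higher number from compound 3 to compound 4 (0.04 log units; within the scatter) in this assay. The change therefore reads the same on the two cores shown, with no difference between the steps that can be told apart from ordinary scatter: the same change on two cores in this assay, a 1.1-fold higher number (0.03 log units; within the scatter) from compound 1 to compound 2 and a 1.1-fold higher number (0.04 log units; within the scatter) from compound 3 to compound 4, 1.0-fold (0.01 log units) apart, within the scatter of two such steps. This shows that, for these two pairs, the change leaves the number in this assay without a readable shift, but it does not show that the change has no effect at all, since a small real shift would be hidden in the scatter, and two cores are too few to support a rule for the wider series.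

Still open, going by these compounds, is whether other groups on the same amine nitrogen, such as an acetyl, a methylsulfonyl or a longer alkyl chain, would also stay within the scatter of the free amine on both cores. Also open, on these data alone, is whether the flat steps hold on a core carrying other groups on its aromatic rings, such as a methoxy or a nitrile, and whether they hold in any read-out beyond this one.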